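The source may hold more compounds than are shown below. What is called first, only, known or untested is meant among the compounds shown, and "the series" means these compounds.

In a functional assay on the whole organism (strain albino) for inhibition, with Rattus norvegicus as the target, read by paw edema, with a stated time of 4 h, at a dose of 0.28 mmol/kg by the oral route (on this read-out lower numbers stand for less inhibition and higher numbers for more inhibition at the one dose given (going by the name of the read-out)), three compounds of one series have been measured. Compound 1 `C=CCn1c(SCC(=O)c2ccccc2)nnc1-c1ccccc1` gives 66%. Compound 2 `C=CCn1c(SC/C(=N\O)c2ccccc2)nnc1-c1ccc(OC)c(OC)c1` gives 78%. Compound 3 `COc1ccc(-c2nnc(SC/C(=N/O)c3ccccc3)n2-c2ccccc2)cc1` gives 80%, the highest number of the three, although compound 2 lies within the scatter of it, so no order between those two can be read; only compound 1 stands clearly lower, beyond the scatter.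

The step now followed leads from compound 3 to compound 4 `O/N=C(/CSc1nnc(-c2ccccc2)n1-c1ccccc1)c1ccccc1`, which has not yet been measured in this assay. The change is small: hydrogen in place of methoxy on an aromatic carbon. Among the measured compounds shown here, no step between measured compounds isolates this difference, so its size must be judged from the series as a whole. For the measured compounds named here, compound 1, the one measured compound without the methoxy, gives 66%, which is lower than compound 3, but it differs in other places as well, so this is only a loose guide.

Compound 4 is therefore expected to sit somewhat lower than compound 3, with an expected step of a number 10 percentage points lower from compound 3 to compound 4 (within the scatter) that may not exceed the scatter. For compound 4 the estimate in this assay is 70%, within a range from 55% to 82%.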

Compound 4, a percentage reported as inhibition, in the whole organism at one dose (the size of the read-out at that dose, not a potency): 79%
Compound 4: middle estimate off by 9 percentage points, on the low side; low and high end bracket the measured number.
By their numbers in this assay, from the lowest: compound 1; then compounds 2, 4 and 3 (each within the scatter of the next).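

In this assay, among the compounds shown here, the step of a number 1 percentage points lower from compound 3 to compound 4 (within the scatter) is the first to isolate one change, hydrogen in place of methoxy on an aromatic carbon, para to a large group. For this pair, 4-methoxyphenyl and phenyl therefore cannot be told apart at the one dose given, and the methoxy group is not needed to reach a read-out of this size. Nothing at hand explains why the two compounds read alike.

On these data alone, whether a different group at this position, such as an amine, a carboxylic acid or a longer alkoxy chain, would shift the read-out remains open. For the compounds shown here, it is also open whether the same change would read alike on another compound of the series, since this single pair is the only evidence for it.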